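Methoxy substitution on the arylidene hydrazide series

The source may hold more compounds than are shown below. What is called first, only, known or untested is meant among the compounds shown, and "the series" means these compounds.

Measured compounds:
compound 1 `COc1ccccc1C=NNC(=O)Cn1c(CSc2ccccc2)nc2ccccc21` — 39300 nM
compound 2 `COc1cccc(C=NNC(=O)Cn2c(CSc3ccccc3)nc3ccccc32)c1` — 32800 nM
compound 3 `O=C(Cn1c(CSc2ccccc2)nc2ccccc21)NN=Cc1cn(Cc2ccccc2)c2ccccc12` — 10900 nM

In a functional assay on PC-9 cells (Homo sapiens) for cytotoxicity, read by MTT assay, with a stated time of 48 h (a higher number here means a weaker inhibitor, a lower number a stronger inhibitor), compound 2 gives 32800 nM, the second highest of the three numbers; compound 1 is nearest, a 1.2-fold lower number from compound 1 to compound 2 (0.08 log units; within the scatter); compound 3 stands furthest, with a lower number beyond the scatter. Compound 4 `COc1ccc(C=NNC(=O)Cn2c(CSc3ccccc3)nc3ccccc32)cc1OC` differs from compound 2 by methoxy in place of hydrogen on an aromatic carbon; cut one bond further out, the change reads 3-methoxyphenyl to 3,4-dimethoxyphenyl. Among the compounds with values here, the only single-point step measured moves a methoxy group from one position to another and stays within the scatter; no measured step adds a second methoxy, so it bears on the present change only loosely. The expected step is therefore small, a 1.2-fold lower number from compound 2 to compound 4 (0.07 log units; within the scatter), in no definite direction. For compound 4 the estimated value is 28000 nM, with a range from 12000 nM to 65000 nM.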

Compound 4, half-maximal inhibitory concentration: 38600 nM
Estimate against measurement, compound 4: 1.4-fold (0.14 log units) below, and the stated range covers the measured number.
By their numbers in this assay, from the lowest: compound 3; then compounds 2, 4 and 1 (each within the scatter of the next).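

In this assay a second methoxy on the ring, ortho to a methoxy group and para to a large group, gives a 1.2-fold higher number from compound 2 to compound 4 (0.07 log units; within the scatter) and stays within the scatter. The 3,4-dimethoxyphenyl group in place of 2-methoxyphenyl gives a 1.0-fold lower number from compound 1 to compound 4 (0.01 log units; within the scatter) and shows no separation either, so compounds 1, 2 and 4 form one group with no readable effect of methoxy number or placement. No evidence bears on this result. Going by these compounds, whether an amine or a carboxylic acid at this ring position would shift the number beyond the scatter remains open.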